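Chain lengthening at the tertiary alcohol of compound 2

The source may hold more compounds than are shown below. What is called first, only, known or untested is meant among the compounds shown, and "the series" means these compounds.

Compounds with measured values:
`CCCCC(O)CC(=O)O[C@H](CC=C(C)C)C1=CC(=O)c2c(O)ccc(O)c2C1=O` compound 1, 72200 nM
`CCC(C)(O)CC(=O)O[C@H](CC=C(C)C)C1=CC(=O)c2c(O)ccc(O)c2C1=O` compound 2, 25200 nM
`CC(C)=CC[C@@H](OC(=O)CC(C)(O)C(C)C)C1=CC(=O)c2c(O)ccc(O)c2C1=O` compound 3, 27700 nM

Three esters of the shared core were tested in a functional assay on HeLa cells (Homo sapiens) for cytotoxicity, read by MTT assay; on this read-out lower numbers stand for stronger inhibition and higher numbers for weaker inhibition. Compound 2 gives the lowest number of the three, but compound 3 sits within the scatter of it (a 1.1-fold higher number from compound 2 to compound 3 (0.04 log units; within the scatter)), so the two cannot be ranked; only compound 1 stands apart, at a higher number (a 2.9-fold lower number from compound 1 to compound 2 (0.46 log units; beyond the scatter)).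

The unmeasured compound 4 has the structure `CCCCC(C)(O)CC(=O)O[C@H](CC=C(C)C)C1=CC(=O)c2c(O)ccc(O)c2C1=O`. Compared with compound 2 the change is:
ethyl in place of hydrogen on a saturated chain carbon, three bonds along the chain from an oxygen on a saturated carbon
Cut one bond further out, the same difference reads 1-hydroxy-1-methylpropyl to 1-hydroxy-1-methylpentyl.

Going by the values given here, two measured steps bear on this. Adding a methyl on the side chain of compound 2 gave a 1.1-fold higher number from compound 2 to compound 3 (0.04 log units; within the scatter), a change within the scatter. Replacing 1-hydroxypentyl with 1-hydroxy-1-methylpropyl gave a 2.9-fold lower number from compound 1 to compound 2 (0.46 log units; beyond the scatter), a modest step. Compound 4 keeps the tertiary alcohol of compound 2 and extends the chain toward the length of compound 1, so a small step toward higher numbers, or none beyond the scatter, is expected.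

Compound 4 is therefore estimated at 32000 nM in this assay, with a range from 13000 nM to 80000 nM, which is expected to be a step of a 1.3-fold higher number from compound 2 to compound 4 (0.10 log units; within the scatter).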

Compound 4, half-maximal inhibitory concentration: 60600 nM
Beside the measured number, compound 4's estimate is 1.9-fold (0.28 log units) below it; the measured number falls inside the stated range.
By their numbers in this assay, from the lowest: compounds 2 and 3 (each within the scatter of the next); then compounds 4 and 1 (each within the scatter of the next).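

The earlier compounds shown here showed only that a methyl added on the side chain of compound 2 changed nothing beyond the scatter; compound 4 shows that ethyl in place of hydrogen on the saturated chain carbon, three bonds along the chain from an oxygen on a saturated carbon, does move the number in this assay, with a 2.4-fold higher number from compound 2 to compound 4 (0.38 log units; beyond the scatter). Butyl in place of isopropyl likewise gives a 2.2-fold higher number from compound 3 to compound 4 (0.34 log units; beyond the scatter), so among these four compounds the two with the longer chain, compound 1 and compound 4, both sit apart from compound 2 and compound 3, with no compound going against this. The tertiary alcohol alone does not restore the lower number, since methyl in place of hydrogen on the alcohol carbon gives only a 1.2-fold lower number from compound 1 to compound 4 (0.08 log units; within the scatter), and that methyl change reads as neutral on both cores: the same change on two cores in this assay, a 1.1-fold higher number (0.04 log units; within the scatter) from compound 2 to compound 3 and a 1.2-fold lower number (0.08 log units; within the scatter) from compound 1 to compound 4, 1.3-fold (0.12 log units) apart, within the scatter of two such steps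

The compounds shown leave open how the number responds to a chain of intermediate length, such as propyl, or to a longer chain, such as hexyl, on that carbon. Open too, as far as these compounds go, is what an amine in place of the hydroxyl would do.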